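The source may report more compounds than this note shows. Statements on the series, on what has been measured and on what is new or still open speak of the compounds shown alone.

Going by the values given here, in a functional assay on the whole organism for inhibition, with Scenedesmus acutus as the target (a lower number here means a stronger inhibitor, a higher number a weaker inhibitor), compound 2 `S=c1n(-c2ccccc2)c(=S)n2n1CCCC2` gives 7940 nM, the higher of the two numbers measured so far, which makes it the weaker inhibitor of the pair. The other measured compound is compound 1 `S=c1n(-c2ccc(Cl)cc2)c(=S)n2n1CCCC2`, which gives 61.7 nM. These two differ in one place, and the step of a 130-fold higher number from compound 1 to compound 2 (2.11 log units; beyond the scatter) is large and beyond the scatter, with hydrogen in place of chloro on an aromatic carbon.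

Compound 3 `S=c1n(-c2ccc(Br)cc2)c(=S)n2n1CCCC2` has not yet been measured. Its change from compound 2 is bromo in place of hydrogen on an aromatic carbon, para to a large group. Among the compounds with values here, only one measured step bears on this change, and it swaps hydrogen and a different halogen, so the comparison is suggestive rather than direct. Read in reverse, that step points to a large fall in the number in this assay, towards the 61.7 nM of compound 1. The expected step is a 110-fold lower number from compound 2 to compound 3 (2.05 log units; beyond the scatter). For compound 3, the estimated value is 70 nM, with an expected range of 20 nM to 300 nM.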

Compound 3, half-maximal inhibitory concentration: 64.6 nM
For compound 3 the middle estimate is 1.1-fold (0.03 log units) above the measured one, within the range that was stated.
By their numbers in this assay, from the lowest: compounds 1 and 3 (each within the scatter of the next); then compound 2.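

In this assay, the large effect of a halogen on this aromatic carbon, para to a large group, is not unique to chloro: bromo in place of hydrogen gives a 120-fold lower number from compound 2 to compound 3 (2.09 log units; beyond the scatter) and so matches the size of the earlier step with chloro. Exchanging one halogen for the other gives only a 1.0-fold higher number from compound 1 to compound 3 (0.02 log units; within the scatter) and stays within the scatter, so compounds 1 and 3 cannot be told apart here, and both stand well apart from compound 2, which carries hydrogen at this place. Nothing available here explains why either halogen has so large an effect at this place.

The compounds shown cannot say whether this effect belongs to halogens alone or would also appear with another group at this place, such as methyl, methoxy or a nitrile, nor whether fluoro or iodo would fit alongside chloro and bromo. They also leave open whether chloro or bromo on a different carbon of the same aromatic ring would give a similar result.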